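The source may report more compounds than this note shows. Statements on the series, on what has been measured and on what is new or still open speak of the compounds shown alone.

Compound 3, with the structure `C/N=C(\S)NCCCn1nc(-c2ccccc2)ccc1=O`, gives 38.9% in a functional assay on the whole organism with Rattus norvegicus as the target, at a dose of 100 mg/kg (on this read-out higher numbers stand for more inhibition at the one dose given (going by the name of the read-out) and lower numbers for less inhibition), the highest of the three numbers recorded there. Compound 2, `C/N=C(\S)NCCCCCCn1nc(-c2ccccc2)ccc1=O`, gives 22.2%, and compound 1, `C/N=C(/NC#N)NCCCn1nc(C)ccc1=O`, gives 6.8%, both beyond the scatter below compound 3. Going by the values given here, the one single-place step among the measured compounds is a number 16.7 percentage points higher from compound 2 to compound 3 (beyond the scatter), a shortening of the chain that carries the ring, and it does not touch the ring substituent.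

Compound 4, `C/N=C(\S)NCCCn1nc(C)ccc1=O`, is reached from compound 3 by methyl in place of phenyl on an aromatic carbon. Among the compounds with values here, no measured step bears directly on this change. Compound 1 also carries the methyl, but it differs from compound 3 in more than one place, so its low value cannot be read as the effect of the methyl alone; it shows only that, with a different chain end, compound 1 gave 6.8%. The account therefore expects a drop for compound 4, though of uncertain size, given that compound 1 with the methyl sits well below compound 3.

The expected step is a number 16.9 percentage points lower from compound 3 to compound 4 (beyond the scatter) for compound 4. Compound 4 is estimated to give 22% in this assay, with a range from 5% to 40%.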

Compound 4, a percentage reported as inhibition, in the whole organism at one dose (the size of the read-out at that dose, not a potency): -8.2%
Beside the measured number, compound 4's estimate is 30.2 percentage points above it, outside the stated range (below it).
By their numbers in this assay, from the lowest: compound 4; then compound 1; then compound 2; then compound 3.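

Going by these compounds alone, on the shared core, methyl in place of phenyl on the aromatic carbon next to the ring nitrogen gives a number 47.1 percentage points lower from compound 3 to compound 4 (beyond the scatter) in this assay, so this position, which no earlier single-place step had touched, carries a large change, larger than the step for the shorter chain, a number 16.7 percentage points higher from compound 2 to compound 3 (beyond the scatter) in the same read-out. With the methyl held constant, the exchange on the amine nitrogen gives a number 15 percentage points lower from compound 1 to compound 4 (beyond the scatter) and shows that the group at the chain end also moves the number, so the low value of compound 1 is now set against a partner that differs from it in one place only, though this step is smaller than the one for the loss of phenyl. Nothing among the data shown explains why either change has the effect it has. The compounds shown place only phenyl and methyl on this aromatic carbon, so they leave open how an ethyl or a benzyl group there would read. They also leave open whether the step between the two chain ends would keep its direction and size with phenyl on the ring in place of methyl, since that pair is available only with the methyl.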